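Swapping the Benzimidazole Substituent on a Substance-P Antagonist

A few compounds are considered here, and "the series" means these few. Any claim that something is new, unique, unknown or untested is made for them only; others in the source may bear on it.

Measured compounds:
- compound 1, `COC(=O)c1ccc(Cn2c(C(=O)C3CCN(CCC4(c5ccc(OC)c(OC)c5)CCN(C(=O)c5cc(OC)c(OC)c(OC)c5)C4)CC3)nc3ccccc32)cc1`: 7.63 nM
- compound 2, `CCOCCn1c(C(=O)C2CCN(CCC3(c4ccc(F)cc4)CCN(Cc4cc(OC)c(OC)c(OC)c4)C3=O)CC2)nc2ccccc21`: 6.93 nM

Of the compounds shown here, two have been measured in a functional assay for antagonist activity at Substance-P receptor (Cavia porcellus); on this read-out higher numbers stand for weaker inhibition and lower numbers for stronger inhibition. Compound 1 gives 7.63 nM and compound 2 gives 6.93 nM. Compound 1 holds the higher of the two numbers, but its distance to compound 2 falls within the scatter, so nothing separates them on this read-out. For the measured compounds named here, the two structures differ in several places at once, so no single step links them.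

Compound 3, `CCOCCn1c(C(=O)C2CCN(CCC3(c4ccc(OC)c(OC)c4)CCN(C(=O)c4cc(OC)c(OC)c(OC)c4)C3)CC2)nc2ccccc21`, has not been measured. It keeps the core of compound 1 and takes on the change (ethoxymethyl in place of 4-(methoxycarbonyl)phenyl on a saturated chain carbon bound to an aromatic nitrogen), which brings the group found at that place in compound 2 onto the framework of compound 1. Going by the values given here, no measured pair isolates this change. Since compound 2, which carries the entering group, gives 6.93 nM, a number that matches compound 1, the step from compound 1 to compound 3 is expected to stay within the scatter, with no clear direction. Compound 3 is therefore estimated at 7.5 nM, with a range of 2.5 nM to 22 nM, and the expected step is a 1.0-fold lower number from compound 1 to compound 3 (0.01 log units; within the scatter).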

Compound 3, half-maximal inhibitory concentration: 7.39 nM
Estimate against measurement, compound 3: 1.0-fold (0.01 log units) above; low and high end bracket the measured number.
By their numbers in this assay, from the lowest: compounds 2, 3 and 1 (each within the scatter of the next).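

In this assay, the change from 4-(methoxycarbonyl)benzyl to 2-ethoxyethyl gives a 1.0-fold lower number from compound 1 to compound 3 (0.01 log units; within the scatter) and is the only pair shown that isolates a change at this place. On the core of compound 1, this read-out therefore does not separate the two groups, even though the entering ethoxymethyl has 4 heavy atoms and no ring, while the leaving 4-(methoxycarbonyl)phenyl has 10 heavy atoms and a six-membered aromatic ring of carbon only. Nothing available explains why the two groups cannot be told apart here.

This single pair does not show whether a benzyl group without the ester, a carboxylic acid on that benzyl ring, an amine at the end of the chain or a longer alkoxyalkyl chain would also stay within the scatter. For the compounds shown here, it also leaves open whether the same exchange would behave in the same way on a different core, as no second pair tests it elsewhere.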